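The source may report more compounds than this note shows. Statements on the series, on what has been measured and on what is new or still open speak of the compounds shown alone.

Of the compounds shown here, two have so far been measured in a functional assay on the whole organism with Rattus norvegicus as the target, read by paw edema, with a stated time of 3 h, at a dose of 100 mg/kg by the oral route; a higher number here means more inhibition at the dose given (going by the name of the read-out), a lower number less inhibition. Compound 1, `Cc1cccc(-c2nc3cc(Cl)ccc3[nH]2)n1`, gives 39% in this assay. Compound 2, `Cc1ccc(-c2nc3ccccc3n2CCN(C)C)nc1`, gives 12%. Compound 2 thus stands at the lower of the two numbers, and its gap to compound 1 lies beyond the scatter of repeated measurements. The two structures differ in more than one place, so nothing more than the two numbers themselves can be read from that pair.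

Compound 3, `Cc1ccc(-c2nc3ccccc3n2CC(=O)N2CCCCC2)nc1`, has not yet been measured. It differs from compound 2 in a single place: (piperidin-1-yl)carbonyl in place of (dimethylamino)methyl on a saturated chain carbon bound to an aromatic nitrogen. Among the compounds with values here, no pair of measured compounds that differ in only one place is available, so there is no measured step of a comparable kind to lean on. Within the data shown here, the only anchor is compound 2 with its 12%. The expected change is a number 8 percentage points higher from compound 2 to compound 3 (within the scatter), which is small and carries no direction that could be told apart from the scatter. Compound 3 is therefore estimated at 20%, within a range from 2% to 42%.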

Compound 3, a percentage reported as inhibition, in the whole organism at one dose (the size of the read-out at that dose, not a potency): 2%
Compound 3: middle estimate off by 18 percentage points, on the high side; low and high end bracket the measured number.
By their numbers in this assay, from the lowest: compounds 3 and 2 (each within the scatter of the next); then compound 1.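

Within the data shown here, this is the first step between measured compounds that differ in one place: on a saturated chain carbon bound to an aromatic nitrogen, (piperidin-1-yl)carbonyl in place of (dimethylamino)methyl gives a number 10 percentage points lower from compound 2 to compound 3 (within the scatter) in this assay. The entering group is larger and brings a six-membered non-aromatic ring and a double bond outside aromatic rings, while the counts of hydrogen-bond donors and acceptors and the net charge stay as they were, yet this read-out does not tell the two compounds apart. Nothing measured here offers an explanation for this result.

Only this one exchange at this place can be read, so the compounds shown do not tell whether a different group there, such as a carboxylic acid, a primary amine or a longer chain ending in a morpholine ring, would move the number beyond the scatter. Compound 1 differs from both of the others in more than one place, so the compounds shown also leave open which of its structural differences goes with its higher number.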